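Replacing 3-bromophenyl by pyridin-2-yl in compound 1

This account rests on a few compounds, and the source may have more. Where it says the series, first, only, none or still open, it means among the compounds named here.

Values in an assay on LM cells for displacement of a labelled ligand from Neuropeptide Y receptor type 5 (Homo sapiens); a lower number here means a stronger inhibitor, a higher number a weaker inhibitor:
- compound 1, `Fc1ccc(C2(c3ccc(F)cc3)CNC(c3cccc(Br)c3)=N2)cc1`: 4.8 nM
- compound 2, `Cc1cccc(C2=NC(c3ccc(F)cc3)(c3ccc(F)cc3)CN2)c1`: 30 nM
- compound 3, `Fc1ccc(C2(c3ccc(F)cc3)CNC(c3cccs3)=N2)cc1`: 54 nM

Compound 1 has the lowest number of the three; the steps away from it are a 6.3-fold higher number from compound 1 to compound 2 (0.80 log units; beyond the scatter) and an 11-fold higher number from compound 1 to compound 3 (1.05 log units; beyond the scatter), both beyond the scatter. Between compounds 2 and 3 the step is a 1.8-fold higher number from compound 2 to compound 3 (0.26 log units; within the scatter).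

Compound 4, `Fc1ccc(C2(c3ccc(F)cc3)CNC(c3ccccn3)=N2)cc1`, differs from compound 1 in one place: pyridin-2-yl in place of 3-bromophenyl on a carbon with a double bond to nitrogen. Both measured steps from compound 1 replace the same 3-bromophenyl group on the same carbon, and both give a clearly higher number in this assay. Pyridin-2-yl is a third such replacement, so a higher number than compound 1, beyond the scatter, is expected.

Compound 4 is therefore estimated at 40 nM (range 12 nM to 150 nM), an expected step of an 8.3-fold higher number from compound 1 to compound 4 (0.92 log units; beyond the scatter).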

Compound 4, half-maximal inhibitory concentration: 160 nM
The estimate for compound 4 lay 4.0-fold (0.60 log units) below the measured number; measured number outside the range, above it.
By their numbers in this assay, from the lowest: compound 1; then compounds 2 and 3 (each within the scatter of the next); then compound 4.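

In this assay, pyridin-2-yl gives the largest loss yet at this carbon (a 33-fold higher number from compound 1 to compound 4 (1.52 log units; beyond the scatter)), so a six-membered aromatic ring alone does not preserve the low number of compound 1. The change also separates compound 4 from both weaker compounds (a 3.0-fold higher number from compound 3 to compound 4 (0.47 log units; beyond the scatter); a 5.3-fold higher number from compound 2 to compound 4 (0.73 log units; beyond the scatter)), making compound 4 the weakest of the four. No available evidence accounts for this loss. Still open, from the compounds shown here alone, is how pyridin-3-yl or pyridin-4-yl would compare at this carbon, which would show whether the place of the ring nitrogen matters.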